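Methyl to methoxy on the fused core of a 5-lipoxygenase inhibitor

The source may hold more compounds than are shown below. What is called first, only, known or untested is meant among the compounds shown, and "the series" means these compounds.

Two compounds share a core in which an aniline nitrogen bridges to a fused bicyclic ring system. Compound 1 `c1ccc(Nc2nc3ccccc3o2)cc1` carries hydrogen on the six-membered carbon ring of that system, and in an assay on isolated protein (strain Balb/c) for inhibition of Polyunsaturated fatty acid 5-lipoxygenase (Mus musculus), read by immunoassay, with a stated time of 20 min (on this read-out lower numbers stand for stronger inhibition and higher numbers for weaker inhibition), compound 1 gives 8910 nM. Compound 2 `Cc1ccc2oc(Nc3ccccc3)nc2c1` carries a methyl there instead, and in this assay compound 2 gives 4600 nM. Within the data shown here, the only measured step between them, a 1.9-fold lower number from compound 1 to compound 2 (0.29 log units; within the scatter), leaves the two numbers inside the usual scatter of each other, so compound 2 cannot be placed apart from compound 1 on these data.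

Compound 3 `COc1ccc2oc(Nc3ccccc3)nc2c1` is the next member. It differs from compound 2 by methoxy in place of methyl on an aromatic carbon. Among the measured compounds shown here, no measured step involves a methoxy, so the sole guide is the step from compound 1 to compound 2, which itself stayed within the scatter. On that basis the step of a 1.0-fold lower number from compound 2 to compound 3 (0.01 log units; within the scatter) is expected to stay within the scatter as well, with no clear direction. Compound 3 is therefore estimated at 4500 nM in this assay, with a range from 1500 nM to 13000 nM.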

Compound 3, half-maximal inhibitory concentration: 7880 nM
For compound 3 the middle estimate is 1.8-fold (0.24 log units) below the measured one, within the range that was stated.
By their numbers in this assay, from the lowest: compounds 2, 3 and 1 (each within the scatter of the next).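

Methoxy brings a second heavy atom and a hydrogen-bond acceptor to this place, on an aromatic carbon meta to a fused ring and para to a fused ring, yet in this assay the exchange for methyl is a 1.7-fold higher number from compound 2 to compound 3 (0.23 log units; within the scatter) and the comparison with the unsubstituted core is a 1.1-fold lower number from compound 1 to compound 3 (0.05 log units; within the scatter). With these steps and the earlier one from hydrogen to methyl all inside the scatter, hydrogen, methyl and methoxy at this place cannot be told apart on these numbers, so adding an oxygen and a hydrogen-bond acceptor here does not separate compound 3 from either compound 1 or compound 2. Nothing given here bears on why the three numbers lie so close together.

The compounds shown leave open whether any group at this place can move the number beyond the scatter, for instance an amine, a carboxylic acid or a longer chain such as butoxy. They also leave open whether a substituent on the aniline ring, which stays unchanged in all three compounds, would separate members of this series.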